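The compounds below may be only part of what the source reports. "The series", "measured", "known", "first", "only" and "open" are said of these compounds alone.

Compound 1 `Fc1ccccc1NC(=S)Nc1cccc(C(F)(F)F)c1` was examined in an ADME assay on MDBK cells (Bos taurus) for cytotoxicity, read by MTT assay, with a stated time of 96 h; a higher number here means that more compound is tolerated, a lower number that less compound is tolerated. In this assay compound 1 gives > 100000 nM, and this figure is a limit of the assay rather than a measured number. Compound 1 therefore stands at the limit of > 100000 nM in this assay, at which 1 of the 2 values shown sits. Among the compounds with values here, the only other measured compound, compound 2 `CC[C@H]1CC[C@H](c2ccc(NC(=S)Nc3cccc(C(F)(F)F)c3)cc2)CC1`, shares the same core but carries a larger group on one nitrogen of that core; in this assay compound 2 gives 9000 nM. Within the data shown here, no step between these two compounds is defined here, so their values can only be set side by side: compound 2 has a number, compound 1 only a limit.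

Compound 3 `Fc1cccc(NC(=S)Nc2cccc(C(F)(F)F)c2)c1` has not yet been measured. It differs from compound 1 by a single rearrangement of the same atoms: 3-fluorophenyl in place of 2-fluorophenyl on an amide-type nitrogen. This change is small, and with only a limit for compound 1 in hand, no shift beyond the usual scatter of this assay is expected. The step expected is a number no higher from compound 1 to compound 3 (the limit leaves the size open), which means essentially no change. For compound 3 the value expected in this assay is 100000 nM, within a range from 30000 nM to 300000 nM, most likely again reported as a limit.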

Compound 3, half-maximal cytotoxic concentration: 10000 nM
The estimate for compound 3 lay 10-fold (1.00 log units) above the measured number; measured number below the stated range.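

Placing 3-fluorophenyl in place of 2-fluorophenyl on the amide-type nitrogen adds and removes no atoms, yet in this assay it gives an at least 10-fold lower number from compound 1 to compound 3 (1.00 log units; beyond the scatter). Within the data shown here, this place on the shared core therefore responds to how the same atoms are arranged, and a larger group, such as the one in compound 2, is not needed for a measurable number to appear in this assay. Compound 1 has only a limit in this assay, so the step gives a minimum size and not an exact one: the limit of > 100000 nM in this assay, at which 1 of the 3 values shown sits.

The compounds shown do not reveal what lies behind this change, since no property that might account for it is given as measured, and a single pair cannot show whether the fluorine's arrangement matters in the same way elsewhere. They also leave open how this assay would respond to a chlorine atom or a methoxy group in place of the fluorine, or to a plain phenyl ring with neither.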